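The source may hold more compounds than are shown below. What is called first, only, known or untested is meant among the compounds shown, and "the series" means these compounds.

Compound 1 `COc1cccc(Nc2cc3[nH]c(-c4cccc(C(F)(F)F)c4)nc3cn2)n1` reaches only a limit in a physicochemical assay for solubility, using the shake flask method, in phosphate buffer, measured as kinetic solubility, with a stated time of 20 h, at pH 6.5 (a lower number here means a less soluble compound, a higher number a more soluble compound), < 5000 nM. Compound 2 `N#Cc1ccc(Nc2cc3[nH]c(-c4cccc(C(F)(F)F)c4)nc3cn2)nc1` likewise sits at a limit in this assay, < 5000 nM. Among the compounds with values here, the one measured step, a step that the two limits leave unreadable from compound 1 to compound 2, has no readable size because both values rest on (the limit of < 5000 nM in this assay, at which 2 of the 2 values shown sit). Compound 3 `NC(=O)c1ccc(Nc2cc3[nH]c(-c4cccc(C(F)(F)F)c4)nc3cn2)nc1` differs from compound 2 by carbamoyl in place of cyano on an aromatic carbon. Within the data shown here, no measured step with a readable size bears on this change, so the step that the limit leaves unreadable from compound 2 to compound 3 is expected to stay within the usual scatter. Compound 3 is therefore estimated at 3500 nM, in a range from 800 nM to 15000 nM, with a fair chance that only a limit is reported again.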

Compound 3, solubility: < 5000 nM
Compound 3 gave a limit, no number; the forecaster's own chance of this, stated with the estimate: 65%; the middle value lies beyond the limit too.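

No step among compound 1, compound 2 and compound 3 can be read, because all three values are limits: the limit of < 5000 nM in this assay, at which 3 of the 3 values shown sit.

The compounds shown leave open how these three compare in this assay, and what carbamoyl in place of cyano does there.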